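This account rests on a few compounds, and the source may have more. Where it says the series, first, only, none or still open, it means among the compounds named here.

Measured so far in an assay on isolated protein for inhibition of cytosolic endo-beta-N-acetylglucosaminidase (Homo sapiens), tested at 1000 uM; a higher number here means more inhibition at the concentration tested (going by the name of the read-out), a lower number less inhibition:
compound 1 `O=C(O)[C@H]1NC[C@H](O)[C@H](O)[C@@H]1O` gives 26%
compound 2 `O=C(O)[C@H]1NC[C@@H](O)[C@@H](O)[C@@H]1O` gives 28%
compound 3 `O=C(O)[C@@H]1NC[C@@H](O)[C@@H](O)[C@@H]1O` gives 2.1%

All three compounds share the same atoms and bonds and differ only in how their ring carbons are configured. Compound 1 stands second highest of the three: the step of a number 2 percentage points higher from compound 1 to compound 2 (within the scatter) is within the scatter, while a number 23.9 percentage points lower from compound 1 to compound 3 (beyond the scatter) and a number 25.9 percentage points lower from compound 2 to compound 3 (beyond the scatter) are beyond it. Compound 4 `O=C(O)[C@@H]1NC[C@H](O)[C@H](O)[C@H]1O` is a further configurational isomer; against compound 1 the change is the two compounds have the same atoms and bonds and differ only in configuration as drawn: 2 of 4 stereo elements differ; a stereocentre at a saturated ring carbon is drawn S in compound 1 and R in compound 4; a stereocentre at a saturated ring carbon is drawn R in compound 1 and S in compound 4. The steps seen so far show that flipping ring configurations can leave this assay unchanged or lower it modestly, so a drop of uncertain size is the most that can be anticipated. Compound 4 is therefore expected to give about 15%, in a range from 2% to 35%. That estimate corresponds to an expected step of a number 11 percentage points lower from compound 1 to compound 4 (beyond the scatter).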

Compound 4, a percentage reported as inhibition, at one concentration (the size of the read-out at that concentration, not a potency): 39%
The estimate for compound 4 lay 24 percentage points below the measured number, outside the stated range (above it).
By their numbers in this assay, from the lowest: compound 3; then compounds 1 and 2 (each within the scatter of the next); then compound 4.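

In this assay, within the data shown here, changing configuration alone can also raise the number, which no earlier step showed beyond the scatter: a number 13 percentage points higher from compound 1 to compound 4 (beyond the scatter). The assay also tells a pair of mirror images apart, with a number 11 percentage points higher from compound 2 to compound 4 (beyond the scatter). Among these compounds, the widest step so far is a number 36.9 percentage points higher from compound 3 to compound 4 (beyond the scatter), and compound 4 now stands above the other three.

Going by these compounds, compounds 1 and 4 differ at two stereocentres together, and the share of each in the rise stays open. Also open, on these data alone, is whether a methyl ester in place of the carboxylic acid would keep this order.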